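The source may report more compounds than this note shows. Statements on the series, on what has been measured and on what is new or still open speak of the compounds shown alone.

In a functional assay on HOS-TE85 cells (Homo sapiens) for inhibition, read by CCK-8 assay, with a stated time of 72 h (on this read-out lower numbers stand for stronger inhibition and higher numbers for weaker inhibition), three compounds with a shared core have been measured. Compound 1 (`COc1ccccc1N1C(=O)CSC1c1cccc(C(=O)NCCCCn2cncn2)c1`) reads > 1000 nM, which is a limit of the assay and not a number. Compound 3 (`O=C(NCCCCn1cccn1)c1cccc(C2SCC(=O)N2c2cccnc2)c1`) reads > 1000 nM, also a limit, and so stands at the limit of > 1000 nM in this assay, at which 2 of the 3 values shown sit. Within the data shown here, compound 2 (`O=C(NCCCCc1ccccc1)c1cccc(C2SCC(=O)N2c2ccccc2)c1`) is the only one with a number, at 15.9 nM. No two of these compounds differ in just one place, so the data offer no direct step to lean on.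

Compound 4 (`O=C(NCCCCn1cccn1)c1cccc(C2SCC(=O)N2c2cc(Cl)ccn2)c1`) has 4-chloropyridin-2-yl in place of the pyridin-3-yl of compound 3, on an amide-type nitrogen in a ring: 4-chloropyridin-2-yl in place of pyridin-3-yl on an amide-type nitrogen in a ring. The rest of the structure is unchanged. A modest move toward stronger inhibition is expected in this assay, though another reading at the limit would be no surprise. That cautious hope rests on compound 2, whose 15.9 nM shows that a low number is reachable with this core. The expected change is an at least 1.6-fold lower number from compound 3 to compound 4 (0.22 log units; that floor lies within the scatter). For compound 4 the estimate is 600 nM, with an expected range of 60 nM to 2500 nM.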

Compound 4, half-maximal inhibitory concentration: 36.4 nM
Compound 4: the middle estimate sits 16-fold (1.22 log units) above what was measured; measured number below the stated range.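

Replacing pyridin-3-yl with 4-chloropyridin-2-yl on the amide-type nitrogen in a ring gives an at least 27-fold lower number from compound 3 to compound 4 (1.43 log units; beyond the scatter) in this assay, the only direct comparison among the compounds shown, and it shows that this one position can move a compound from the limit of the assay to a measured number. Compound 3 reads > 1000 nM, which is a limit and not a number, so the step gives only the smallest size the change can have: the limit of > 1000 nM in this assay, at which 2 of the 4 values shown sit. The amide chain is the same in compound 3 and compound 4, so this chain does not by itself hold a compound at the limit.

The compounds shown leave open whether the chlorine or the change from a pyridin-3-yl to a pyridin-2-yl ring carries the step, a question that a plain pyridin-2-yl or a 4-methylpyridin-2-yl group at this position would address. They also leave open how 4-chloropyridin-2-yl would read when paired with the phenyl-ending chain of compound 2.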